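Replacing the chlorophenyl of compound 3 with a pyridyl ring

The compounds below may be only part of what the source reports. "The series", "measured", "known", "first", "only" and "open" are said of these compounds alone.

The shared core carries a pyrrolidine amide on a propyl chain attached to a biphenyl. Compound 1 `Cc1ccccc1-c1ccc(CCC(=O)N2CCCC2)cc1` bears a methyl on the outer ring; in an assay on HEK293 cells for inhibition of N-acylethanolamine-hydrolyzing acid amidase (Rattus norvegicus), read by LC-MS, with a stated time of 30 min (on this read-out lower numbers stand for stronger inhibition and higher numbers for weaker inhibition), compound 1 reaches only the limit > 100000 nM. Compound 2 `O=C(CCc1ccc(-c2ccccc2F)cc1)N1CCCC1` carries a fluoro instead, and in this assay compound 2 gives 2800 nM. Compound 3 `O=C(CCc1ccc(-c2ccccc2Cl)cc1)N1CCCC1` carries a chloro; in this assay compound 3 likewise reaches only the limit > 100000 nM. Thus compound 3 stands at the top of the range shown, at the limit of > 100000 nM in this assay, at which 2 of the 3 values shown sit. The steps measured are an at least 35-fold lower number from compound 1 to compound 2 (1.55 log units; beyond the scatter), an at least 35-fold higher number from compound 2 to compound 3 (1.55 log units; beyond the scatter) and a step that the two limits leave unreadable from compound 1 to compound 3.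

Compound 4 `O=C(CCc1ccc(-c2ccccn2)cc1)N1CCCC1` differs from compound 3 by pyridin-2-yl in place of 2-chlorophenyl on an aromatic carbon. Among the compounds with values here, no measured step exchanges a whole aryl ring for a pyridyl ring, so the measured steps bear on it only indirectly: they show that the outer ring with a fluoro gives a readable number whereas methyl and chloro give limits. Compound 4 is therefore expected to land between those outcomes, estimated at 12000 nM with a range from 1500 nM to 100000 nM. The expected step is an at least 8.3-fold lower number from compound 3 to compound 4 (0.92 log units; beyond the scatter), downward, though a limit remains possible.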

Compound 4, half-maximal inhibitory concentration: > 100000 nM
Compound 4: no number, only a limit (the forecaster's own chance of this, stated with the estimate: 35%); middle value at least 8.3-fold (0.92 log units) away from the limit.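

In this assay compound 4 gives > 100000 nM, which is a limit of the assay and not a number. Exchanging 2-fluorophenyl for pyridin-2-yl gives an at least 35-fold higher number from compound 2 to compound 4 (1.55 log units; beyond the scatter), while the steps from compound 1 and from compound 3 to compound 4 cannot be read, with limits at both ends. On this aromatic carbon, the 2-fluorophenyl of compound 2 remains the only group shown with a readable value, and pyridin-2-yl joins 2-methylphenyl and 2-chlorophenyl at the ceiling: the limit of > 100000 nM in this assay, at which 3 of the 4 values shown sit.

Going by these compounds, how far compound 1, compound 3 and compound 4 differ from one another beyond that limit remains open. Also open, on these data alone, is how an unsubstituted phenyl, a pyridin-3-yl or a 2-methoxyphenyl would read at this place.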